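The compounds below may be only part of what the source reports. "The series", "measured", "known", "first", "only" and "open" are said of these compounds alone.

Measured so far in an assay on HEK293 cells for inhibition of Voltage-dependent T-type calcium channel subunit alpha-1G (Homo sapiens), read by patch clamp; on this read-out lower numbers stand for stronger inhibition and higher numbers for weaker inhibition:
compound 1, `O=C(CCCN1CCN(c2ccccc2)CC1)Nc1ccc(Cl)cc1`, 4470 nM
compound 2, `O=C(CCCN1CCN(c2ccccc2Cl)CC1)Nc1ccc(Cl)cc1`, 6010 nM

Compound 2 gives the highest of the two numbers, and its nearest neighbour is compound 1, a 1.3-fold higher number from compound 1 to compound 2 (0.13 log units; within the scatter). Going by the values given here, with only two measured compounds, compound 2 is not to be called weaker than compound 1: the two stand within the scatter of each other.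

The next compound is compound 3, `COc1ccccc1N1CCN(CCCC(=O)Nc2ccc(Cl)cc2)CC1`. Against compound 2 the change is methoxy in place of chloro on an aromatic carbon. Among the compounds with values here, no measured step puts a methoxy group in place of a chloro group; the only step available is the one from compound 1 to compound 2, which exchanged hydrogen for chloro at the same place, and that step stayed within the scatter, a 1.3-fold higher number from compound 1 to compound 2 (0.13 log units; within the scatter). On that basis the substituent at this place has so far made no difference beyond the scatter, and the same is expected here: no change beyond the scatter in this assay, a 1.2-fold lower number from compound 2 to compound 3 (0.08 log units; within the scatter). Compound 3 is therefore estimated at 5000 nM in this assay, with a range from 2000 nM to 13000 nM.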

Compound 3, half-maximal inhibitory concentration: 2610 nM
Compound 3: the middle estimate sits 1.9-fold (0.28 log units) above what was measured; low and high end bracket the measured number.
By their numbers in this assay, from the lowest: compounds 3, 1 and 2 (each within the scatter of the next, the first and the last beyond it).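

Going by these compounds alone, at the place ortho to a large group, the substituent now registers in this assay: going from 2-chlorophenyl to 2-methoxyphenyl gives a 2.3-fold lower number from compound 2 to compound 3 (0.36 log units; beyond the scatter), the first step beyond the scatter, though a modest one. Measured against hydrogen at the same place, methoxy does not separate, with a 1.7-fold lower number from compound 1 to compound 3 (0.23 log units; within the scatter), so the only readable difference so far lies between the two substituents, and neither stands apart from the unsubstituted compound 1. The entering methoxy carries 1 hydrogen-bond acceptor where chloro carries 0, but nothing available ties the step to that count or to any other feature of the change.

The three compounds leave open whether the separation between chloro and methoxy extends to other groups at this place, such as a hydroxyl, an amine or a longer ethoxy chain. They also leave open whether methoxy would give a similar number at another carbon of the same ring, and whether any change at this place can move the series beyond the scatter from compound 1.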